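A Longer Ester Chain on a Shared Core

A few compounds are considered here, and "the series" means these few. Any claim that something is new, unique, unknown or untested is made for them only; others in the source may bear on it.

Compound 1, `C=CCOC(=O)C1=C(C)NC(C)=C(C(=O)OC)C1c1ccccc1[N+](=O)[O-]`: 10 nM
Compound 2, `C=C(C)CCOC(=O)C1=C(C)NC(C)=C(C(=O)OC)C1c1cccc([N+](=O)[O-])c1`: 47 nM

In a functional assay on HEK293 cells for antagonist activity at Voltage-dependent L-type calcium channel subunit alpha-1D (Rattus norvegicus), read by FLIPR (on this read-out lower numbers stand for stronger inhibition and higher numbers for weaker inhibition), compound 1 gives 10 nM and compound 2 gives 47 nM. Compound 2 thus stands at the higher of the two numbers, and the gap between them lies beyond the usual scatter. Compound 3, `COC(=O)C1=C(C)NC(C)=C(C(=O)OCCCCc2ccc(OC)cc2)C1c1cccc([N+](=O)[O-])c1`, has not been measured. It differs from compound 2 in one place: 2-(4-methoxyphenyl)ethyl in place of 1-methylethenyl on a saturated chain carbon, two bonds along the chain from an oxygen next to a carbonyl group. Among the measured compounds shown here, no measured pair shows a change of this kind, so no step in this assay can be read from the data. The change is expected to give a 1.2-fold lower number from compound 2 to compound 3 (0.07 log units; within the scatter), with no firm direction. Compound 3 is estimated at 40 nM, within 10 nM to 160 nM.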

Compound 3, half-maximal inhibitory concentration: 38 nM
Compound 3: the middle estimate sits 1.1-fold (0.02 log units) above what was measured; the measured number falls inside the stated range.
By their numbers in this assay, from the lowest: compound 1; then compounds 3 and 2 (each within the scatter of the next).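

The swap of 1-methylethenyl for 2-(4-methoxyphenyl)ethyl gives a 1.2-fold lower number from compound 2 to compound 3 (0.09 log units; within the scatter) in this assay and so leaves the two compounds indistinguishable. At this saturated chain carbon, then, a group with far more heavy atoms and a six-membered aromatic ring fits with no measurable cost in this read-out. Nothing measured here accounts for this result. The compounds shown leave open whether an amine or a carboxylic acid in the same place would behave alike, and whether a longer chain would.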